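The compounds below may be only part of what the source reports. "The series", "measured", "known", "first", "only" and "open" are said of these compounds alone.

Compound 1 `CCOC(=O)c1ccc(-c2nn(C)c3ccccc23)cc1` is the smallest member of the series. In a functional assay on cells (Platelet, Homo sapiens) for inhibition (a higher number here means a weaker inhibitor, a lower number a stronger inhibitor), compound 1 gives > 10000 nM, which is a limit of the assay and not a number. Compound 2 `CCOC(=O)c1ccc(-c2nn(Cc3ccc(Cl)cc3)c3ccccc23)cc1` carries a 4-chlorophenyl in place of hydrogen on a saturated chain carbon bound to an aromatic nitrogen, and in this assay compound 2 gives > 10000 nM, again a limit. Compound 3 `CCOC(=O)c1ccc(-c2nn(Cc3ccc(OC)cc3)c3ccccc23)cc1` carries a 4-methoxyphenyl in place of hydrogen on a saturated chain carbon bound to an aromatic nitrogen; in this assay compound 3 gives > 10000 nM, also a limit. Compound 3 therefore stands together with the other two at the edge of what the assay reports, since (the limit of > 10000 nM in this assay, at which 3 of the 3 values shown sit). The steps a step that the two limits leave unreadable from compound 1 to compound 2, a step that the two limits leave unreadable from compound 1 to compound 3 and a step that the two limits leave unreadable from compound 2 to compound 3 are all of unreadable size for that reason. Compound 4 `CCOC(=O)c1ccc(-c2nn(-c3ccccc3)c3ccccc23)cc1` differs from compound 3 by phenyl in place of 4-methoxybenzyl on an aromatic nitrogen. Within the data shown here, no measured step bears readably on this change; what the data show is that every variation tried so far on the aromatic nitrogen has left the value at the limit. Compound 4 is expected to stay at the limit too, with the step that the limit leaves unreadable from compound 3 to compound 4 estimated as not readable in size. For compound 4 in this assay the estimate is 20000 nM, within 5000 nM to 100000 nM.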

Compound 4, half-maximal inhibitory concentration: > 10000 nM
Compound 4 ended at the assay's limit (the forecaster's own chance of this, stated with the estimate: 85%); the middle value lies beyond the limit too.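

Among these compounds, no step among compound 1, compound 2, compound 3 and compound 4 can be read in this assay, because all four stand at the same limit: (the limit of > 10000 nM in this assay, at which 4 of the 4 values shown sit). The compounds shown leave open how methyl, 4-chlorobenzyl, 4-methoxybenzyl and phenyl on the aromatic nitrogen compare, and what change to the shared core would bring a value within the assay's reported range.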